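Swapping an aryl group on a weak end of the series

This account rests on a few compounds, and the source may have more. Where it says the series, first, only, none or still open, it means among the compounds named here.

Measured in a functional assay on SEM cells (Homo sapiens) for cytotoxicity, with a stated time of 72 h; a lower number here means that less compound is needed, a higher number that more compound is needed for the effect:
- Compound 1 `COc1ccc(/C=C/[C@@](C)(/C=C/c2ccc(O)c(/C=C/C(C)=O)c2)CCC=C(C)C)cc1`: 8670 nM
- Compound 2 `COc1ccc(/C=C/[C@@](C)(/C=C/c2ccc(O)c(/C=C/C(=O)c3ccccc3)c2)CCC=C(C)C)cc1`: 36600 nM
- Compound 3 `COc1ccc(/C=C/[C@@](C)(/C=C/c2ccc(O)cc2)CCC=C(C)C)cc1`: > 36600 nM, a limit

Compound 3 stands at the limit of > 36600 nM in this assay, at which 1 of the 3 values shown sits. No number is therefore known for it, only a limit. Compound 4 `CC(C)=CCC[C@](C)(/C=C/c1ccc(O)cc1)/C=C/c1cccc(Cl)c1` keeps most of compound 3 and changes one group, with 3-chlorophenyl in place of 4-methoxyphenyl on a double-bonded chain carbon bound to a double-bonded chain carbon.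

For the measured compounds named here, none of the measured steps touches this place. They concern the other end of the molecule. Hydrogen in place of 2-acetylethenyl gave an at least 4.2-fold higher number from compound 1 to compound 3 (0.62 log units; beyond the scatter), and phenyl in place of methyl on a carbonyl carbon gave a 4.2-fold higher number from compound 1 to compound 2 (0.63 log units; beyond the scatter). Hydrogen in place of 2-benzoylethenyl gave a number no lower from compound 2 to compound 3 (the limit leaves the size open). Compound 4, like compound 3, carries neither of these ethenyl groups, so the steps place it at the weak end of the series but give no size for the swap itself.

No step beyond the usual scatter is therefore expected in either direction in this assay, and another limit is quite possible. The expected change is a step that the limit leaves unreadable from compound 3 to compound 4. The estimate for compound 4 is 40000 nM, with an expected range from 15000 nM to 90000 nM.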

Compound 4, half-maximal effective concentration: > 36600 nM
Compound 4 ended at the assay's limit (the forecaster's own chance of this, stated with the estimate: 60%); the middle value is on the limit's open side.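

In this assay compound 4 gives > 36600 nM, which is a limit and not a number. Compound 3 also has only a limit, and no step can be read between compound 3 and compound 4. What 3-chlorophenyl in place of 4-methoxyphenyl does to the number, in either direction, stays open among the compounds shown.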